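Pyridin-3-yl Replaces Pyrazol-3-yl at the Terminal Aromatic Position

This account rests on a few compounds, and the source may have more. Where it says the series, first, only, none or still open, it means among the compounds named here.

Measured so far in a functional assay on MV4-11 cells (Homo sapiens) for antiproliferative activity, with a stated time of 6 days, tested at 6.25 uM; a lower number here means a weaker effect, a higher number a stronger effect of the compound at the concentration tested:
- compound 1, `CNC(=O)N1CCCc2ccc(NC(=O)c3ccc(-c4ccncc4)cc3)cc21`, gives 88.7%
- compound 2, `CNC(=O)N1CCCc2ccc(NC(=O)c3ccc(-c4cnn(C(C)=O)c4)cc3)cc21`, gives 83.8%
- compound 3, `CNC(=O)N1CCCc2ccc(NC(=O)c3ccc(-c4cc[nH]n4)cc3)cc21`, gives 99.1%

Compound 3 stands highest of the three numbers. Its nearest neighbour is compound 1, with a step of a number 10.4 percentage points higher from compound 1 to compound 3 (beyond the scatter), and its furthest is compound 2, with a step of a number 15.3 percentage points higher from compound 2 to compound 3 (beyond the scatter); both steps lie beyond the scatter. The step of a number 4.9 percentage points lower from compound 1 to compound 2 (within the scatter) lies within the scatter, so compound 1 and compound 2 cannot be ordered against each other.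

Compound 4, `CNC(=O)N1CCCc2ccc(NC(=O)c3ccc(-c4cccnc4)cc3)cc21`, has not yet been measured in this assay. It differs from compound 3 in one place: pyridin-3-yl in place of 1H-pyrazol-3-yl on an aromatic carbon. Within the data shown here, no measured step makes this exact exchange. Among the measured compounds shown here, the step that bears on it most is the one from a six-membered group to the pyrazolyl, a number 10.4 percentage points higher from compound 1 to compound 3 (beyond the scatter), which was modest. Returning to a six-membered group of the kind in compound 1 is therefore expected to give a modest decrease, a number 11.1 percentage points lower from compound 3 to compound 4 (beyond the scatter). Compound 4 is estimated at 88%, with a range from 72% to 99%.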

Compound 4, a percentage reported as inhibition, at one concentration (the size of the read-out at that concentration, not a potency): 92.1%
Compound 4: middle estimate off by 4.1 percentage points, on the low side; the measured number falls inside the stated range.
By their numbers in this assay, from the lowest: compounds 2, 1, 4 and 3 (each within the scatter of the next, the first and the last beyond it).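

In this assay, the exchange of 1H-pyrazol-3-yl for pyridin-3-yl, with 1 hydrogen-bond donor leaving and 0 hydrogen-bond donors entering, gives a number 7 percentage points lower from compound 3 to compound 4 (within the scatter) and so does not separate the two compounds. The other new comparisons are also unresolved, with a number 3.4 percentage points higher from compound 1 to compound 4 (within the scatter) for the exchange of pyridin-4-yl for pyridin-3-yl and a number 8.3 percentage points higher from compound 2 to compound 4 (within the scatter) for the exchange of 1-acetyl-1H-pyrazol-4-yl for pyridin-3-yl. The gap between compound 1 and compound 3 therefore does not extend to a general difference between six-membered and five-membered rings at this position.

Nothing available explains these readings. Going by these compounds, whether a terminal carboxylic acid, an aliphatic amine or a longer chain would hold the effect at this single concentration remains open.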